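Cytotoxicity Limit Holds Across an Aryl Swap

The compounds below may be only part of what the source reports. "The series", "measured", "known", "first", "only" and "open" are said of these compounds alone.

Compound 1 `COC(=O)N[C@H](C(=O)NN(CCC[C@@](O)(Cc1ccccc1)C(=O)N[C@H]1c2ccccc2C[C@H]1O)CC(C)C)C(C)(C)C` was tested in an ADME assay on MT4 cells (Homo sapiens) for cytotoxicity; a lower number here means that less compound is tolerated, a higher number that more compound is tolerated. In this assay compound 1 gives only a limit, > 10000 nM, not a number. Compound 1 thus stands at the limit of > 10000 nM in this assay, at which 2 of the 2 values shown sit. Compound 2 `COC(=O)N[C@H](C(=O)NN(CCC[C@@](O)(Cc1ccccc1)C(=O)N[C@H]1c2ccccc2C[C@H]1O)Cc1ccc(-c2nc(C(C)(C)C)cs2)cc1)C(C)(C)C` likewise gives only a limit in this assay, > 10000 nM. Compound 3 `COC(=O)N[C@H](C(=O)NN(CCC[C@@](O)(Cc1ccccc1)C(=O)N[C@H]1c2ccccc2C[C@H]1O)Cc1ccc(-c2cccnc2)cc1)C(C)(C)C` is not yet measured; it differs from compound 1 by 4-(pyridin-3-yl)phenyl in place of isopropyl on a saturated chain carbon bound to an amine nitrogen. For the measured compounds named here, with no measured step to lean on, the step that the limit leaves unreadable from compound 1 to compound 3 is expected to stay within the scatter. This expectation rests on compound 2, whose value in this assay is also a limit, > 10000 nM. Compound 3 is expected to give about 20000 nM, between 8000 nM and 60000 nM.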

Compound 3, half-maximal cytotoxic concentration: > 10000 nM
Compound 3: only a limit was reported; the forecaster's own chance of this, stated with the estimate: 80%; the middle value is on the limit's open side.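

Compound 3 also gives only a limit in this assay, so the steps to it from compound 1 and compound 2 cannot be read: the limit of > 10000 nM in this assay, at which 3 of the 3 values shown sit.

From the compounds shown here alone, whether compound 1, compound 2 and compound 3 differ at all in how much of each is tolerated stays open.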